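From 4-methoxybenzyl to 2-fluorobenzyl: compound 3 to compound 4

The source may report more compounds than this note shows. Statements on the series, on what has been measured and on what is new or still open speak of the compounds shown alone.

In an ADME assay on KB cells (Homo sapiens) for cytotoxicity (on this read-out lower numbers stand for an effect already at smaller amounts and higher numbers for an effect only at larger amounts of compound), compound 1 (`COc1cc2c(c(OC)c1OC)C(=O)[C@]1(OC)C=C[C@H]2N(C(=O)OCC(C)C)N1C(=O)OCC(C)C`) gives > 300 ug/mL, a limit of the assay and not a number. Compound 2 (`COc1cc2c(c(OCc3ccc(F)cc3)c1OC)C(=O)[C@]1(OC)C=C[C@H]2N(C(=O)OCC(C)C)N1C(=O)OCC(C)C`) gives > 300 ug/mL, again a limit. Going by the values given here, compound 3 (`COc1ccc(COc2c(OC)c(OC)cc3c2C(=O)[C@]2(OC)C=C[C@H]3N(C(=O)OCC(C)C)N2C(=O)OCC(C)C)cc1`) gives 47.9 ug/mL, the only actual number so far.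

Compound 4 (`COc1cc2c(c(OCc3ccccc3F)c1OC)C(=O)[C@]1(OC)C=C[C@H]2N(C(=O)OCC(C)C)N1C(=O)OCC(C)C`) carries 2-fluorophenyl in place of the 4-methoxyphenyl of compound 3, on a saturated chain carbon bound to an oxygen on an aromatic ring: 2-fluorophenyl in place of 4-methoxyphenyl on a saturated chain carbon bound to an oxygen on an aromatic ring.

The closest measured change is methoxy in place of fluoro on an aromatic carbon, which gave an at least 6.2-fold lower number from compound 2 to compound 3 (0.79 log units; beyond the scatter). Adding 4-methoxyphenyl to the parent gave an at least 6.2-fold lower number from compound 1 to compound 3 (0.79 log units; beyond the scatter). The step with 4-fluorophenyl cannot be sized, being a step that the two limits leave unreadable from compound 1 to compound 2. Among the compounds with values here, no measured pair covers 2-fluorophenyl itself, so the fluoro analogue compound 2 is only a partial guide.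

Losing the methoxy should therefore reverse at least part of the gain, and a reading at the limit of > 300 ug/mL in this assay, at which 2 of the 3 values shown sit, remains quite possible. The expected step is a 3.5-fold higher number from compound 3 to compound 4 (0.55 log units; beyond the scatter). For compound 4 the estimated value is 170 ug/mL, with an expected range of 60 ug/mL to 300 ug/mL.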

Compound 4, concentration for half-maximal effect: 109 ug/mL
The estimate for compound 4 lay 1.6-fold (0.19 log units) above the measured number; low and high end bracket the measured number.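

At this position on the shared core, in this assay, a measurable number no longer depends on the 4-methoxybenzyl group: 2-fluorobenzyl also gives an at least 2.7-fold lower number from compound 1 to compound 4 (0.43 log units; beyond the scatter). Fluoro as such therefore does not keep a compound at the limit, since 2-fluorophenyl in place of 4-fluorophenyl gives an at least 2.7-fold lower number from compound 2 to compound 4 (0.43 log units; beyond the scatter), so the place of the fluoro on the phenyl ring changes the read-out. Methoxy is still not matched, as 2-fluorophenyl in place of 4-methoxyphenyl gives a 2.3-fold higher number from compound 3 to compound 4 (0.36 log units; beyond the scatter).

As far as these compounds go, the steps from compound 1 and compound 2 start from limits of the assay and not from numbers, so their true size stays open: the limit of > 300 ug/mL in this assay, at which 2 of the 4 values shown sit. Also open, from the compounds shown here alone, is how an amine or a carboxylic acid on the phenyl ring, or a longer chain carrying that ring, would read here.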